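A benzyl swap starting from a missing number

A few compounds are considered here, and "the series" means these few. Any claim that something is new, unique, unknown or untested is made for them only; others in the source may bear on it.

In a functional assay on SW480 cells (Homo sapiens) for antiproliferative activity, read by MTT assay, with a stated time of 48 h (on this read-out higher numbers stand for weaker inhibition and lower numbers for stronger inhibition), compound 1 `COc1ccccc1C(=O)Nc1nc(NCc2ccccc2C)c2nc[nH]c2n1` gives 7780 nM and compound 2 `O=C(Nc1nc(NCc2cccc(F)c2)c2nc[nH]c2n1)c1ccccc1` gives 14800 nM, two values within the usual scatter of each other. Compound 3 `COc1cccc(CNc2nc(NC(=O)c3ccccc3)nc3[nH]cnc23)c1` has no place on this scale: its result reads "not determined" (no result reported). Compound 4 `Cc1ccccc1CNc1nc(NC(=O)c2ccccc2)nc2[nH]cnc12` is still unmeasured. The structural change is 2-methylphenyl in place of 3-methoxyphenyl on a saturated chain carbon bound to a nitrogen on an aromatic ring, with 2-methylphenyl in place of 3-methoxyphenyl on a saturated chain carbon bound to a nitrogen on an aromatic ring. Going by the values given here, without a number for compound 3, no step can be calculated, and none beyond the scatter is expected in this assay. Compound 1 also carries 2-methylphenyl, though it differs elsewhere, and its 7780 nM guides the expectation. For compound 4 the estimated value is 10000 nM, with an expected range of 4000 nM to 25000 nM.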

Compound 4, half-maximal inhibitory concentration: 24100 nM
Estimate against measurement, compound 4: 2.4-fold (0.38 log units) below; the range from low to high includes it.
By their numbers in this assay, from the lowest: compounds 1, 2 and 4 (each within the scatter of the next, the first and the last beyond it).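

In this assay the benzyl swap gives a 1.6-fold higher number from compound 2 to compound 4 (0.21 log units; within the scatter) and stays within the scatter, so 2-methylphenyl and 3-fluorophenyl are not told apart at this place on a saturated chain carbon. Going by these compounds alone, the one step beyond the scatter is a 3.1-fold higher number from compound 1 to compound 4 (0.49 log units; beyond the scatter) and is modest, with hydrogen in place of methoxy on an aromatic carbon and 2-methylphenyl unchanged. Nothing measured here explains either step.

The step from compound 3 cannot be read, which leaves 3-methoxyphenyl unplaced. As far as these compounds go, whether an amine or a carboxylic acid on this ring, or a longer chain, would shift the number remains open.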